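Bromo to methyl in a series of limits

The source may hold more compounds than are shown below. What is called first, only, known or untested is meant among the compounds shown, and "the series" means these compounds.

Measured so far:
compound 1 `CCOCCOC(=O)C(=O)Nc1nc(-c2cc(Br)no2)cs1`: > 30 mg/kg, a limit
compound 2 `COCCOC(=O)C(=O)Nc1nc(-c2cc(Br)no2)cs1`: > 100 mg/kg, a limit
compound 3 `CCOC(=O)C(=O)Nc1nc(-c2cc(Br)no2)cs1`: > 100 mg/kg, a limit

In a functional assay on the whole organism with Rattus norvegicus as the target (a lower number here means that less compound is needed, a higher number that more compound is needed for the effect), compound 3 stands at > 100 mg/kg, which is a limit and not a number. That limit is the limit of > 100 mg/kg in this assay, at which 2 of the 3 values shown sit.

Compound 4 `CCOC(=O)C(=O)Nc1nc(-c2cc(C)no2)cs1` differs from compound 3 in one place: methyl in place of bromo on an aromatic carbon.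

The measured steps are a step that the two limits leave unreadable from compound 1 to compound 2, a step that the two limits leave unreadable from compound 1 to compound 3 and a step that the two limits leave unreadable from compound 2 to compound 3. All three concern the saturated chain and not the bromo group, and none has a readable size. Within the data shown here, no measured step therefore bears directly on methyl in place of bromo on an aromatic carbon.

Compound 3 offers only its limit of > 100 mg/kg as a starting point. No change beyond the scatter can be expected from this evidence, and no direction can be assigned. The expected step is an at least 1.2-fold lower number from compound 3 to compound 4 (0.09 log units; that floor lies within the scatter).

For compound 4 the estimated value in this assay is 80 mg/kg, with an expected range from 20 mg/kg to 300 mg/kg.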

Compound 4, dose for half-maximal effect: 0.7 mg/kg
Compound 4: middle estimate off by 110-fold (2.06 log units), on the high side; measured number outside the range, below it.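

In this assay, among these compounds, the change from 3-bromo-1,2-oxazol-5-yl to 3-methyl-1,2-oxazol-5-yl gives an at least 140-fold lower number from compound 3 to compound 4 (2.15 log units; beyond the scatter), the only readable step so far. This step is a floor and not a full size, because compound 3 carries a limit and not a number: the limit of > 100 mg/kg in this assay, at which 2 of the 4 values shown sit. The steps in the saturated chain among compound 1, compound 2 and compound 3 cannot be read, so the aromatic carbon next to the ring nitrogen is the one place shown where a single change separates a limit from a measured number.

On these data alone, whether this result is specific to methyl stays open: hydrogen, ethyl, methoxy or an amine at this position would test that. Also open, as far as these compounds go, is how the chains of compound 1 and compound 2 behave with methyl in place of bromo.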